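The source may hold more compounds than are shown below. What is called first, only, known or untested is meant among the compounds shown, and "the series" means these compounds.

Compound 1 `Cc1ccc2nc(NC(=S)Nc3ccccc3)sc2c1`: in a functional assay on B16-F10 cells (Mus musculus) for cytotoxicity, read by MTT assay, with a stated time of 48 h (a lower number here means a stronger inhibitor, a higher number a weaker inhibitor), compound 1 gives > 50000 nM, which is a limit of the assay and not a number.
Compound 2 `Fc1ccc2nc(Nc3nc4c(Cl)cccc4s3)sc2c1`: in this assay compound 2 gives > 50000 nM, again a limit.
Compound 3 `Cc1ccc2nc(NC(=S)Nc3ccc(F)cc3)sc2c1`: in this assay compound 3 gives > 50000 nM, also a limit.

Compound 1 therefore has no definite place on the numbers shown: its own reading in this assay is a limit, and the two other values are limits too, so that the limit of > 50000 nM in this assay, at which 3 of the 3 values shown sit, describes the whole set. The step from compound 1 to compound 4 `Fc1ccc2nc(NC(=S)Nc3ccccc3)sc2c1` is fluoro in place of methyl on an aromatic carbon. Among the compounds with values here, the only measured step that bears on it is a step that the two limits leave unreadable from compound 1 to compound 3, and its size cannot be read, since both of its ends sit at the limit. Within the data shown here, no measured step thus gives either a size or a direction for the change in this assay. Compound 4 is expected to sit at the limit as well, with an estimate of 70000 nM and a range from 30000 nM to 200000 nM. The expected step that the limit leaves unreadable from compound 1 to compound 4 is accordingly one of no readable size.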

Compound 4, half-maximal inhibitory concentration: > 50000 nM
Compound 4 ended at the assay's limit; the forecaster's own chance of this, stated with the estimate: 90%; the middle value is on the limit's open side.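

Within the data shown here, compound 1 and compound 4 both sit at a limit of the assay and not at a number, so no step between them can be read in this assay: the limit of > 50000 nM in this assay, at which 4 of the 4 values shown sit. The compounds shown leave open whether fluoro in place of methyl changes anything in this assay.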